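Taking the methyl group off compound 3

A few compounds are considered here, and "the series" means these few. Any claim that something is new, unique, unknown or untested is made for them only; others in the source may bear on it.

- compound 1 `CC(C)(C)c1ccc(C(=O)Nc2ccc(Br)nc2C(=O)O)cc1` gives > 50000 nM (a limit of the assay)
- compound 2 `CC(C)(C)c1ccc(C(=O)Nc2cc(Cl)cnc2C(N)=O)cc1` gives > 50000 nM (a limit of the assay)
- compound 3 `Cc1ccc(C(=O)Nc2cc(Cl)cnc2C(=O)O)cc1` gives 18200 nM (a measured number)

All three results come from an ADME assay on HFF cells (Homo sapiens) for cytotoxicity, with a stated time of 72 h (on this read-out higher numbers stand for lower toxicity in this test and lower numbers for higher toxicity in this test), and describe how much of a compound it takes to harm these cells. For the measured compounds named here, compound 3 at 18200 nM holds the only true number in the set. The other two results share the limit of > 50000 nM in this assay, at which 2 of the 3 values shown sit, and such a limit is not a number. Compound 3 is therefore the single firm reference point here.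

Compound 4 `O=C(Nc1cc(Cl)cnc1C(=O)O)c1ccccc1` is compound 3 with one small edit: hydrogen in place of methyl on an aromatic carbon. Going by the values given here, no pair of measured compounds differs in a single place, so the data offer no direct guide to the size of this step. The edit removes only one heavy atom, so no movement beyond the usual scatter is expected in this assay and no clear direction can be named. The estimate is a 1.2-fold higher number from compound 3 to compound 4 (0.08 log units; within the scatter) and this expected step is small. In this assay the estimated value for compound 4 is 22000 nM (expected range 9000 nM to 45000 nM).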

Compound 4, half-maximal cytotoxic concentration: > 50000 nM
Compound 4 gave a limit, no number; the forecaster's own chance of this, stated with the estimate: 15%; middle value at least 2.2-fold (0.35 log units) away from the limit.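

Taking the methyl group away from this aromatic carbon, para to a large group, is the first change in a single place that can be read in this assay, and it gives an at least 2.7-fold higher number from compound 3 to compound 4 (0.43 log units; beyond the scatter). Within this pair, one methyl group at this position is enough to move the result beyond the usual scatter, and the compound that keeps the methyl group is the one that harms the cells at a measurable concentration. Compound 4 gives > 50000 nM, which is a limit of the assay and not a number, so the step has a known minimum but no known full size, and compound 4 now shares its reading with most of the set: the limit of > 50000 nM in this assay, at which 3 of the 4 values shown sit.

The compounds shown leave open whether an ethyl chain, a methoxy group or an amine on this same carbon would give a measurable number, as methyl does, or reach the limit, as hydrogen does. For the compounds shown here, they also leave open whether the methyl group has the same effect on other versions of the core, since compound 3 and compound 4 form the only pair here that differs in one place.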